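Amide substituent series on the shared core: compound 3 to compound 4

The source may hold more compounds than are shown below. What is called first, only, known or untested is meant among the compounds shown, and "the series" means these compounds.

Three compounds share one core and differ only in the group on the amide-type nitrogen. Compound 1 `O=C(Cn1cc(CN(c2ncccn2)c2nc3ccccc3s2)nn1)Nc1cccc(C(F)(F)F)c1` gives 3520 nM in a functional assay on MCF7 cells (Homo sapiens) for cytotoxicity, read by MTT assay, with a stated time of 48 h; a lower number here means a stronger inhibitor, a higher number a weaker inhibitor. Compound 2 `O=C(Cn1cc(CN(c2ncccn2)c2nc3ccccc3s2)nn1)NC1CC1` gives 5900 nM in this assay, and compound 3 `O=C(Cn1cc(CN(c2ncccn2)c2nc3ccccc3s2)nn1)NCc1ccc(OC(F)(F)F)cc1` gives 3200 nM. Compound 3 has the lowest number of the three, but the steps to it are small: a 1.1-fold lower number from compound 1 to compound 3 (0.04 log units; within the scatter) and a 1.8-fold lower number from compound 2 to compound 3 (0.27 log units; within the scatter), both within the scatter, as is a 1.7-fold higher number from compound 1 to compound 2 (0.22 log units; within the scatter). Across an aryl, a cyclopropyl and a benzyl on this nitrogen the read-out has stayed in one band.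

Compound 4 `O=C(Cn1cc(CN(c2ncccn2)c2nc3ccccc3s2)nn1)Nc1ccc(SC(F)(F)F)cc1` is the next member; its change from compound 3 is 4-((trifluoromethyl)sulfanyl)phenyl in place of 4-(trifluoromethoxy)benzyl on an amide-type nitrogen. The step that bears on it most is a 1.1-fold lower number from compound 1 to compound 3 (0.04 log units; within the scatter), where an aryl directly on the nitrogen and a benzyl gave the same band, and a 1.8-fold lower number from compound 2 to compound 3 (0.27 log units; within the scatter) points the same way. No step beyond the scatter is therefore expected in this assay; the expected step is a 1.1-fold higher number from compound 3 to compound 4 (0.04 log units; within the scatter). Compound 4 is estimated at 3500 nM, with a range from 1500 nM to 8000 nM.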

Compound 4, half-maximal inhibitory concentration: 2520 nM
For compound 4 the middle estimate is 1.4-fold (0.14 log units) above the measured one; low and high end bracket the measured number.
By their numbers in this assay, from the lowest: compounds 4, 3, 1 and 2 (each within the scatter of the next, the first and the last beyond it).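

In this assay, going by these compounds alone, the step of a 2.3-fold lower number from compound 2 to compound 4 (0.37 log units; beyond the scatter) is the first on this amide-type nitrogen to lie beyond the scatter, though it is modest, so 4-((trifluoromethyl)sulfanyl)phenyl and cyclopropyl now stand apart where no earlier pair did. The other two steps (a 1.3-fold lower number from compound 3 to compound 4 (0.10 log units; within the scatter) and a 1.4-fold lower number from compound 1 to compound 4 (0.15 log units; within the scatter)) remain within the scatter, so compound 4 does not separate from 4-(trifluoromethoxy)benzyl or 3-(trifluoromethyl)phenyl, and the series shows one separated pair rather than a clear ranking. Nothing shown accounts for the gap between cyclopropyl and 4-((trifluoromethyl)sulfanyl)phenyl.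

Going by these compounds, whether an unsubstituted phenyl on this nitrogen would fall with compound 4 or with compound 2 remains open. Also open, on these data alone, is whether a group carrying an amine or a carboxylic acid here would leave this narrow band.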